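Hydroxamate series: cap change at the amide nitrogen

A few compounds are considered here, and "the series" means these few. Any claim that something is new, unique, unknown or untested is made for them only; others in the source may bear on it.

Measured so far in a functional assay on NFF cells (Homo sapiens) for antiproliferative activity; a lower number here means a stronger inhibitor, a higher number a weaker inhibitor:
- compound 1 `CN(C)c1ccc(NC(=O)[C@H](CCCCCC(=O)NO)NC(=O)/C=C/c2ccccc2)cc1` gives 240 nM
- compound 2 `CN(C)c1ccc(NC(=O)[C@H](CCCCCC(=O)NO)NC(=O)c2ccc(C(F)(F)F)cc2)cc1` gives 400 nM

Among the compounds with values here, compound 2 and compound 1 differ only at the carbonyl carbon, and the one measured step there, a 1.7-fold higher number from compound 1 to compound 2 (0.22 log units; within the scatter), leaves the two within the scatter of each other. Compound 2 is thus not separated from compound 1 on this assay.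

Compound 3 `O=C(CCCCC[C@H](NC(=O)c1ccc(C(F)(F)F)cc1)C(=O)Nc1cccc2cccnc12)NO` arises from compound 2 by quinolin-8-yl in place of 4-(dimethylamino)phenyl on an amide-type nitrogen. Within the data shown here, no measured step touches this position; the only step seen, a 1.7-fold higher number from compound 1 to compound 2 (0.22 log units; within the scatter), concerns the carbonyl carbon and does not bear on the amide nitrogen. The data therefore give no ground to expect a shift beyond the scatter in either direction for this assay. The estimate for compound 3 is 400 nM, with a range from 120 nM to 1300 nM. This estimate means an expected step of no change at the digits printed from compound 2 to compound 3 (within the scatter), within the scatter.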

Compound 3, half-maximal inhibitory concentration: 696 nM
Compound 3: middle estimate off by 1.7-fold (0.24 log units), on the low side; low and high end bracket the measured number.
By their numbers in this assay, from the lowest: compounds 1, 2 and 3 (each within the scatter of the next, the first and the last beyond it).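

In this assay, within the data shown here, the first step at the amide-type nitrogen, a 1.7-fold higher number from compound 2 to compound 3 (0.24 log units; within the scatter), does not separate quinolin-8-yl from 4-(dimethylamino)phenyl. This position therefore accepts an exchange of a single six-membered aromatic ring of carbon for a two-ring group with a ring nitrogen and loses the dimethylamino group, with no shift beyond the scatter in this assay. No measurement at hand offers an explanation for how the two groups compare at this position.

Open, going by these compounds, is whether a plain phenyl or a pyridin-3-yl on the same nitrogen would give a number beyond the scatter of these two groups. Also open, on these data alone, is whether quinolin-8-yl behaves the same with 2-phenylethenyl on the carbonyl carbon, and whether a longer chain to the hydroxamic acid would shift the number.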